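Bromo to cyano on the pyridine of compound 2

The compounds below may be only part of what the source reports. "The series", "measured", "known", "first", "only" and "open" are said of these compounds alone.

Of the compounds shown here, three have been measured in a functional assay on CHO-K1 cells for antagonist activity at C-X-C chemokine receptor type 3 (Homo sapiens), read by FLIPR and calcium flux; on this read-out higher numbers stand for weaker inhibition and lower numbers for stronger inhibition. Compound 1 `C[C@@H]1CN(c2ccc(C(F)(F)F)cn2)[C@@H](C)CN1S(=O)(=O)C[C@]12CC[C@H](CC1=O)C2(C)C` gives 6310 nM. Compound 2 `CC1(C)[C@@H]2CC[C@@]1(CS(=O)(=O)N1CCN(c3ccc(Br)cn3)CC1)C(=O)C2` gives 1580 nM. Compound 3 `C[C@@H]1CN(S(=O)(=O)C[C@]23CC[C@H](CC2=O)C3(C)C)CCN1c1ccc(C(F)(F)F)cn1` gives 501 nM. Compound 2 thus stands second highest of the three numbers: compound 3 sits well beyond the scatter on the stronger side, compound 1 well beyond the scatter on the weaker side.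

Compound 4 `CC1(C)[C@@H]2CC[C@@]1(CS(=O)(=O)N1CCN(c3ccc(C#N)cn3)CC1)C(=O)C2` is not yet measured in this assay. It differs from compound 2 only in one place: cyano in place of bromo on an aromatic carbon, two atoms from the ring nitrogen. Among the compounds with values here, no measured pair shows this exchange, so no step size is available from the data. Compound 2 and compound 3 differ in several places at once and tell nothing about the bromo-to-cyano change by itself.

The expectation for compound 4 is a modest step from compound 2 toward stronger inhibition, a 1.6-fold lower number from compound 2 to compound 4 (0.20 log units; within the scatter), though a result within the scatter of compound 2 is also plausible. Compound 4 is estimated at 1000 nM in this assay, with a range from 300 nM to 4000 nM.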

Compound 4, half-maximal inhibitory concentration: > 31600 nM
Compound 4: only a limit was reported; the forecaster's own chance of this, stated with the estimate: 5%; middle value at least 31-fold (1.49 log units) away from the limit.
By their numbers in this assay, from the lowest: compound 3; then compound 2; then compound 1. At a limit, above all of these: compound 4.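

Cyano in place of bromo on this aromatic carbon, para to a large group, brings an at least 20-fold higher number from compound 2 to compound 4 (1.30 log units; beyond the scatter) in this assay, the only single-place step in the series so far. The earlier compounds shown here differ in several places at once and could not isolate this position; this step shows that inhibition on the core of compound 2 depends strongly on the group held there. For compound 4 the reported value is a limit, so the step fixes only a minimum size: the limit of > 31600 nM in this assay, at which 1 of the 4 values shown sits.

The compounds shown do not reveal whether the sharp change is specific to cyano or extends to other replacements for bromo, such as chlorine, a methyl or a carboxamide. They also leave open how a methoxy at this position would read on the same core.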